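The compounds below may be only part of what the source reports. "The series", "measured", "known", "first", "only" and "open" are said of these compounds alone.

Measured in an ADME assay on MT4 cells (Homo sapiens) for activation, read by MTT assay; a higher number here means that more compound is tolerated, a lower number that less compound is tolerated:

- Compound 1 `Cc1c(Cc2c(F)cccc2Cl)nc(SC(C)C)[nH]c1=O` gives > 76000 nM
- Compound 2 `CCCSc1nc(Cc2c(F)cccc2Cl)c(C)c(=O)[nH]1` gives > 76000 nM
- Compound 3 `CCC(C)Sc1nc(Cc2c(F)cccc2Cl)c(C)c(=O)[nH]1` gives > 73000 nM

Each of these entries is a limit and not a number. Compound 3 stands at a limit of its own, > 73000 nM. Compound 1 and compound 2 share a limit: the limit of > 76000 nM in this assay, at which 2 of the 3 values shown sit.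

Compound 4 `CCCCSc1nc(Cc2c(F)cccc2Cl)c(C)c(=O)[nH]1` has not yet been measured. Its difference from compound 3 is butyl in place of sec-butyl on a sulfur, which means butyl in place of sec-butyl on a sulfur.

The closest guide is a step that the two limits leave unreadable from compound 1 to compound 2, which puts propyl in place of isopropyl on a sulfur. Also relevant is a step that the two limits leave unreadable from compound 2 to compound 3, which links a straight chain on the sulfur to the sec-butyl of compound 3. Neither has a readable size, so they offer no sign of any change in tolerated concentration.

The expected result is a number no higher from compound 3 to compound 4 (the limit leaves the size open), with no size or direction anticipated beyond the usual scatter. Compound 4 is estimated at 73000 nM, with an expected range from 35000 nM to 110000 nM. The assay will probably report only a limit again.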

Compound 4, half-maximal cytotoxic concentration: > 73000 nM
Compound 4 gave a limit, no number (the forecaster's own chance of this, stated with the estimate: 85%); the middle value lies on the limit itself.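

Compound 4, like compound 1, compound 2 and compound 3, gives only a limit in this assay, and none of the steps linking them can be read. The compounds shown leave open what concentration the cells fail to tolerate, and whether the chain on the sulfur affects it.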